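Swapping an aminoester side chain for a methoxymethyl group

This account rests on a few compounds, and the source may have more. Where it says the series, first, only, none or still open, it means among the compounds named here.

Of the compounds shown here, three that share one core have been tested in a functional assay on HeLa cells (Homo sapiens) for cytotoxicity, read by neutral red uptake, with a stated time of 3 days; on this read-out lower numbers stand for stronger inhibition and higher numbers for weaker inhibition. Compound 1 `CCCCCCc1c(F)c(N)c2c(=O)cc(-c3ccc(N)c(F)c3)oc2c1F` carries a hexyl chain on the core, and in this assay compound 1 gives 21000 nM. Compound 2 `CCOC(=O)c1c(F)c(N)c2c(=O)cc(-c3ccc(N)c(F)c3)oc2c1F` has an ethoxycarbonyl group in that place; in this assay compound 2 reaches only > 100000 nM, which is a limit of the measurement rather than a number (the limit of > 100000 nM in this assay, at which 1 of the 3 values shown sits). Compound 3 `CN(C)CCC(=O)OCc1c(F)c(N)c2c(=O)cc(-c3ccc(N)c(F)c3)oc2c1F` carries a (((2-(dimethylamino)ethyl)carbonyl)oxy)methyl group; in this assay compound 3 gives 11000 nM, the lowest of the two numbers measured, with compound 1 nearest, as a 1.9-fold lower number from compound 1 to compound 3 (0.28 log units; within the scatter) shows. The step of an at least 9.0-fold lower number from compound 2 to compound 3 (0.95 log units; beyond the scatter) is clearly larger.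

Compound 4 `COCc1c(F)c(N)c2c(=O)cc(-c3ccc(N)c(F)c3)oc2c1F` differs from compound 3 by methyl in place of (2-(dimethylamino)ethyl)carbonyl on an oxygen on a saturated carbon. For the measured compounds named here, no measured step removes exactly this group; the closest guide is a 1.9-fold lower number from compound 1 to compound 3 (0.28 log units; within the scatter), where the side chain entered for pentyl without moving the number beyond the scatter, while an at least 9.0-fold lower number from compound 2 to compound 3 (0.95 log units; beyond the scatter) shows that a change on this carbon can matter. A step of a 1.8-fold higher number from compound 3 to compound 4 (0.26 log units; within the scatter) is therefore expected, with a wide range. Compound 4 is estimated at 20000 nM, between 6000 nM and 70000 nM.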

Compound 4, half-maximal inhibitory concentration: > 100000 nM
Compound 4: only a limit was reported; the forecaster's own chance of this, stated with the estimate: 10%; middle value at least 5.0-fold (0.69 log units) from the limit.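

In this assay, replacing the (((2-(dimethylamino)ethyl)carbonyl)oxy)methyl group with methoxymethyl gives an at least 9.0-fold higher number from compound 3 to compound 4 (0.95 log units; beyond the scatter), so an oxygen on this saturated carbon is not enough by itself to keep the number of compound 3, and what sits on that oxygen counts. Methoxymethyl does not stand in for the hexyl chain either, as an at least 4.7-fold higher number from compound 1 to compound 4 (0.67 log units; beyond the scatter) shows, so among these four compounds, measurable numbers appear only with the hexyl chain and the aminoester side chain. Compound 4 gives only a limit of the measurement, as compound 2 does, and the step between these two compounds cannot be read: the limit of > 100000 nM in this assay, at which 2 of the 4 values shown sit.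

The compounds shown leave open whether compound 3 owes its number to the dimethylamino group, to the ester, or to the two together. An acetoxymethyl group, which keeps the ester without the amine, and a 2-(dimethylamino)ethoxymethyl group, which keeps the amine without the ester, would pull these apart, while a butyl chain would test how much of the hexyl chain in compound 1 is needed.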